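Taking the trifluoromethoxy group off compound 2

This account rests on a few compounds, and the source may have more. Where it says the series, first, only, none or still open, it means among the compounds named here.

Two related compounds have been measured in a functional assay on NCI-H460 cells (Homo sapiens) for inhibition, read by sulforhodamine B assay, with a stated time of 48 h; a higher number here means a weaker inhibitor of growth, a lower number a stronger inhibitor of growth. Compound 1 `Ic1ccc(Cn2cc(CCCOc3cccc4cccnc34)nn2)cc1` gives 24.6 ug/mL, while compound 2 `FC(F)(F)Oc1ccc(Cn2cc(CCCOc3cccc4cccnc34)nn2)cc1` gives 10.4 ug/mL, the lower of the two numbers and so the stronger growth inhibition. Compound 3 `c1ccc(Cn2cc(CCCOc3cccc4cccnc34)nn2)cc1` keeps the same core but has hydrogen in place of trifluoromethoxy on an aromatic carbon, a change counted as hydrogen in place of trifluoromethoxy on an aromatic carbon.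

For the measured compounds named here, only one measured step bears on this change. Going a 2.4-fold lower number from compound 1 to compound 2 (0.37 log units; beyond the scatter), trifluoromethoxy replaces iodo on an aromatic carbon, and the step is modest. Going by the values given here, it shows that the group at this carbon can shift the number, but no measured compound shows what a bare hydrogen does there. Since compound 2 holds the lower value at 10.4 ug/mL, losing its group is expected to move the number up rather than down, and by a modest amount. The estimate in this assay is a 2.1-fold higher number from compound 2 to compound 3 (0.33 log units; beyond the scatter), which is uncertain with a single step as a guide. Compound 3 is expected at 22 ug/mL, with an estimated range of 9 ug/mL to 50 ug/mL.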

Compound 3, concentration for 50% growth inhibition: 28.6 ug/mL
For compound 3 the middle estimate is 1.3-fold (0.11 log units) below the measured one; the range from low to high includes it.
By their numbers in this assay, from the lowest: compound 2; then compounds 1 and 3 (each within the scatter of the next).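

Compound 3 gives the bare-hydrogen baseline that was missing, and in this assay removing the trifluoromethoxy group costs a 2.8-fold higher number from compound 2 to compound 3 (0.44 log units; beyond the scatter) as a measured change. This shows that compound 2 stands apart from the unsubstituted ring, so its group does more at this aromatic carbon than merely differ from iodo. The iodo group, by contrast, gives a 1.2-fold higher number from compound 1 to compound 3 (0.07 log units; within the scatter) and so cannot be told apart from hydrogen here, which means that the earlier step from iodo to trifluoromethoxy was in effect a step up from the baseline, and that having just any large atom or group at this carbon does not bring the lower number; nothing given here explains why these groups differ.

For the compounds shown here, with only three groups compared at this carbon, it remains open whether a methoxy group or a trifluoromethyl group, each holding part of trifluoromethoxy, would keep the lower number. From the compounds shown here alone, what an amine or a carboxylic acid would do at the same carbon also stays unknown, so no trend can yet be drawn beyond these compounds.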